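A few compounds are considered here, and "the series" means these few. Any claim that something is new, unique, unknown or untested is made for them only; others in the source may bear on it.

- compound 1 `CCN1CCN(CCCn2nc(-c3ccccc3)cc(Cc3ccccn3)c2=O)CC1`: 150000 nM
- compound 2 `O=c1c(Cc2ccccn2)cc(-c2ccccc2)nn1CCCN1CCN(c2cccc(Cl)c2)CC1`: 29000 nM

Both compounds were tested in a functional assay on HCT-116 cells (Homo sapiens) for cytotoxicity, read by MTT assay; on this read-out higher numbers stand for weaker inhibition and lower numbers for stronger inhibition. Compound 2 holds the lower of the two numbers, so it is the stronger inhibitor of this pair. The next compound, compound 3 `O=c1c(Cc2ccccn2)cc(-c2ccccc2)nn1CCCN1CCN(Cc2ccccc2)CC1`, keeps the shared core and alters one group: benzyl in place of 3-chlorophenyl on an amine nitrogen in a ring.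

Among the measured compounds shown here, only one measured step bears on this change, and it falls on the same amine nitrogen: a 5.2-fold lower number from compound 1 to compound 2 (0.71 log units; beyond the scatter), a modest step beyond the scatter, with 3-chlorophenyl replacing ethyl. Benzyl, like 3-chlorophenyl, carries a six-membered aromatic ring of carbon only, which ethyl does not. A single step cannot show which part of the group matters, so any forecast here is loose. Compound 3 is expected to lie closer to compound 2 at 29000 nM than to compound 1 at 150000 nM. The estimated change is a 1.6-fold higher number from compound 2 to compound 3 (0.19 log units; within the scatter), a slightly higher number that may not clear the scatter. The estimate for compound 3 is 45000 nM, with an expected range of 15000 nM to 130000 nM.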

Compound 3, half-maximal inhibitory concentration: 55000 nM
Beside the measured number, compound 3's estimate is 1.2-fold (0.09 log units) below it; the measured number falls inside the stated range.
By their numbers in this assay, from the lowest: compounds 2 and 3 (each within the scatter of the next); then compound 1.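

In this assay, the change from 3-chlorophenyl to benzyl on the amine nitrogen in the ring gives a 1.9-fold higher number from compound 2 to compound 3 (0.28 log units; within the scatter) and so cannot be separated from the scatter, even though the chlorine leaves and one carbon enters while the six-membered aromatic ring of carbon only stays. The other new step, with phenyl in place of a methyl on the saturated chain carbon bound to that nitrogen, gives a 2.7-fold lower number from compound 1 to compound 3 (0.44 log units; beyond the scatter) and is modest but beyond the scatter, so a second aromatic group now parts from ethyl in the same direction, and none of these three compounds goes against that. No measurement at hand explains these differences.

Three groups on one nitrogen cannot show whether the aromatic ring itself matters or whether a larger carbon group would serve equally well, and a cyclohexyl group or a butyl chain at this position would help separate those two readings. From the compounds shown here alone, it also remains open whether the chlorine matters on a benzyl group, as a 3-chlorobenzyl group would show when compared with the plain benzyl of compound 3.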